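A few compounds are considered here, and "the series" means these few. Any claim that something is new, unique, unknown or untested is made for them only; others in the source may bear on it.

- compound 1 `CC(C)[C@H](NC(=O)COc1cccc2ccccc12)C(=O)N[C@@H](CC(=O)O)C(=O)COC(=O)c1c(Cl)cccc1Cl` gives 11500 nM
- compound 2 `CC(C)[C@H](NC(=O)COc1cccc2ccccc12)C(=O)N[C@@H](CC(=O)O)C(=O)COc1cc(F)cc(F)c1F` gives 11200 nM

Going by the values given here, in a functional assay with Homo sapiens as the target (a lower number here means a stronger inhibitor, a higher number a weaker inhibitor), compound 2 gives 11200 nM and stands level, within the scatter, with the only other measured compound. Next comes compound 3 `CC(C)[C@H](NC(=O)COc1cccc2ccccc12)C(=O)N[C@@H](CC(=O)O)C(=O)COc1cccc(C(F)(F)F)c1F` with the change 2-fluoro-3-(trifluoromethyl)phenyl in place of 2,3,5-trifluorophenyl on an oxygen on a saturated carbon on an oxygen on a saturated carbon. Among the compounds with values here, one measured step bears on this, a replacement at that same place: a 1.0-fold lower number from compound 1 to compound 2 (0.01 log units; within the scatter) stayed within the scatter. Within the data shown here, a single step is thin evidence, and no measured compound carries the entering group. No step beyond the scatter is therefore expected in this assay, in either direction. The expected step is a 1.0-fold lower number from compound 2 to compound 3 (0.01 log units; within the scatter) on this reading. For compound 3 the estimate is 11000 nM with an expected range from 5000 nM to 24000 nM as the working figure.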

Compound 3, half-maximal inhibitory concentration: 18200 nM
The estimate for compound 3 lay 1.7-fold (0.22 log units) below the measured number; low and high end bracket the measured number.
By their numbers in this assay, from the lowest: compounds 2, 1 and 3 (each within the scatter of the next).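

In this assay, 2-fluoro-3-(trifluoromethyl)phenyl in place of 2,3,5-trifluorophenyl gives a 1.6-fold higher number from compound 2 to compound 3 (0.21 log units; within the scatter), so at this place, on an oxygen on a saturated carbon, the group can grow from 9 to 11 heavy atoms without a step beyond the scatter. The comparison with the (2,6-dichlorophenyl)carbonyl group gives a 1.6-fold higher number from compound 1 to compound 3 (0.20 log units; within the scatter), so all three groups now tested at this place sit within the scatter of one another. No measurement on these compounds offers an explanation for this flat result.

Still open, going by these compounds, is whether a group without an aromatic ring at this place, such as an amine or a longer alkyl chain, would give a step beyond the scatter. Also open, on these data alone, is whether a change elsewhere on the shared core, such as an amide in place of the carboxylic acid, would do so.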